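Swapping bromo for fluoro at the assay limit

The compounds below may be only part of what the source reports. "The series", "measured", "known", "first", "only" and "open" are said of these compounds alone.

compound 1 `N#Cc1c(N)cccc1S(=O)(=O)c1ccccc1`: > 5000 nM
compound 2 `N#Cc1c(N)cccc1S(=O)(=O)c1cccc(Cl)c1`: > 200000 nM
compound 3 `N#Cc1c(N)cccc1S(=O)(=O)c1cccc(Br)c1`: > 200000 nM

In a functional assay on MT4 cells (Homo sapiens) for cytotoxicity (a lower number here means a stronger inhibitor, a higher number a weaker inhibitor), compound 3 gives > 200000 nM, which is a limit and not a number. Compound 3 therefore sits at the limit of > 200000 nM in this assay, at which 2 of the 3 values shown sit. Compound 4 `N#Cc1c(N)cccc1S(=O)(=O)c1cccc(F)c1` has not been measured, and it differs from compound 3 by one change: fluoro in place of bromo on an aromatic carbon.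

The nearest evidence is a step that the two limits leave unreadable from compound 2 to compound 3, which swaps one of these substituents for another but gives no size. Neither a step that the two limits leave unreadable from compound 1 to compound 2 nor a step that the two limits leave unreadable from compound 1 to compound 3 gives a size either. Compound 1 also carries only a limit, at the limit of > 5000 nM in this assay, at which 1 of the 3 values shown sits. With no readable step to draw on, no clear shift can be predicted, and the best guide is that compound 2 stands at > 200000 nM, again a limit.

The expected change is a number no higher from compound 3 to compound 4 (the limit leaves the size open), with no real shift in either direction anticipated. Compound 4 is expected to give about 200000 nM, with an estimated range from 40000 nM to 400000 nM, and the assay will probably report only a limit.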

Compound 4, half-maximal inhibitory concentration: > 200000 nM
Compound 4: only a limit was reported (the forecaster's own chance of this, stated with the estimate: 80%); the middle value sits exactly at the limit.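

In this assay, among the compounds shown here, compound 1, compound 2, compound 3 and compound 4 all give only limits, and no step among them can be read. The compounds shown leave open where the true values lie and whether exchanging hydrogen, chloro, bromo or fluoro changes them at all.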